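The source may report more compounds than this note shows. Statements on the series, on what has been measured and on what is new or still open speak of the compounds shown alone.

Among the compounds with values here, in a functional assay on PC-6 cells (Homo sapiens) for cytotoxicity, read by MTT assay, with a stated time of 3 days (a higher number here means a weaker inhibitor, a lower number a stronger inhibitor), compound 1 `CN(C)Cc1ccc(/C=N/Nc2ncnc3sc(C(C)(C)C)cc23)cc1` gives 0.107 ug/mL, the only number available so far. Compound 2 `COC(=O)c1ccc(/C=N/Nc2ncnc3sc(C(C)(C)C)cc23)cc1` has no single number to stand on, its entry reading "not determined" (no result reported). Compound 3 `CC(C)(C)c1cc2c(N/N=C/c3ccc(O)cc3)ncnc2s1` has hydroxy in place of methoxycarbonyl on an aromatic carbon, para to a large group (hydroxy in place of methoxycarbonyl on an aromatic carbon). Since compound 2 provides no starting value, the step can be expected only loosely, as a modest shift toward weaker inhibition in this assay than compound 1 at 0.107 ug/mL. Compound 3 is expected at about 0.4 ug/mL, with an estimated range of 0.07 ug/mL to 3 ug/mL.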

Compound 3, half-maximal inhibitory concentration: > 10 ug/mL
Compound 3 ended at the assay's limit; the forecaster's own chance of this, stated with the estimate: 5%; at least 25-fold (1.39 log units) between middle value and limit.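

In this assay compound 3 gives > 10 ug/mL, which is a limit of the assay and not a number: the limit of > 10 ug/mL in this assay, at which 1 of the 3 values shown sits.

The position para to a large group therefore matters in this assay: hydroxy in place of (dimethylamino)methyl gives an at least 93-fold higher number from compound 1 to compound 3 (1.97 log units; beyond the scatter). Within the data shown here, compound 2 offers no value, so no step involving methoxycarbonyl can be read.

Going by these compounds, how far compound 3 lies past its limit stays open. So does whether a carboxylic acid, a primary amine or a longer aminoalkyl chain on this carbon would read closer to compound 1 or to compound 3.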